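Fluoro for Methyl on the Shared Core of Compound 1

The compounds below may be only part of what the source reports. "The series", "measured", "known", "first", "only" and "open" are said of these compounds alone.

Compound 1 `Cc1ccc2nc(C(=O)Nc3c(F)cc(-c4cccc(F)c4)cc3F)c(C)c(O)c2c1` holds the higher of the two numbers recorded in a functional assay on A-375 cells (Homo sapiens) for antiproliferative activity, read by MTT assay, with a stated time of 24 h, tested at 100 ug/mL (a higher number here means a stronger effect of the compound at the concentration tested, a lower number a weaker effect), where compound 1 gives 56.4%. Among the compounds with values here, its only measured neighbour, compound 2 `CCc1ccc2nc(C(=O)Nc3c(F)cc(-c4cccc(F)c4)cc3F)c(C)c(O)c2c1`, gives 47.3% in that assay; the step of a number 9.1 percentage points lower from compound 1 to compound 2 (within the scatter) lies within the scatter, so the two numbers cannot be told apart. Compound 3 `Cc1c(C(=O)Nc2c(F)cc(-c3cccc(F)c3)cc2F)nc2ccc(F)cc2c1O` differs from compound 1 by a single change: fluoro in place of methyl on an aromatic carbon. Within the data shown here, no measured step covers this exchange; the one step on record, a number 9.1 percentage points lower from compound 1 to compound 2 (within the scatter), concerns a different group at a different place and stayed within the scatter. With nothing pointing in either direction, the expected step of a number 4.4 percentage points lower from compound 1 to compound 3 (within the scatter) is one that does not go beyond the scatter. The estimate for compound 3 in this assay is therefore 52%, with a range from 35% to 70%.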

Compound 3, a percentage reported as inhibition, at one concentration (the size of the read-out at that concentration, not a potency): 51.3%
Compound 3: the middle estimate sits 0.7 percentage points above what was measured; low and high end bracket the measured number.
By their numbers in this assay, from the lowest: compounds 2, 3 and 1 (each within the scatter of the next).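

In this assay the aromatic carbon of the shared core now carries fluoro as well as methyl and ethyl, and the new steps, a number 5.1 percentage points lower from compound 1 to compound 3 (within the scatter) and a number 4 percentage points higher from compound 2 to compound 3 (within the scatter), show that replacing either chain with a halogen does not separate the compounds. Neither methyl, ethyl nor fluoro can therefore be told apart from the others at this position, so the read-out at this one concentration gives no preference among the three groups. Nothing further on record bears on why these numbers lie so close together.

Going by these compounds, it remains open whether any group at this position would move the number beyond the scatter, for instance an amine, a methoxy group, a carboxylic acid or a longer chain. On these data alone, it is also open whether the three compounds would differ in potency, which a read-out at one concentration cannot show.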